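Swapping methylsulfanyl for propyl on a growth-inhibition series

The source may report more compounds than this note shows. Statements on the series, on what has been measured and on what is new or still open speak of the compounds shown alone.

Measured compounds:
Compound 1, `CCOC(=O)C1=C(C)NC(=O)NC1c1ccc(SC)cc1`, 2.5 ug/mL
Compound 2, `CCCc1ccc(C2NC(=S)NC(C)=C2C(=O)OCC)cc1`, 27.7 ug/mL
Compound 3, `CCOC(=O)C1=C(C)NC(=S)NC1c1ccc(SC)cc1`, 5.3 ug/mL

In a functional assay on 786-0 cells (Homo sapiens) for inhibition, read by sulforhodamine B assay, with a stated time of 48 h (a higher number here means a weaker inhibitor of growth, a lower number a stronger inhibitor of growth), compound 1 gives 2.5 ug/mL, the lowest of the three numbers, with compound 3 next at 5.3 ug/mL. Compound 2 is the highest, at 27.7 ug/mL. Compounds 2 and 3 share a core and differ in one place, (propyl in place of methylsulfanyl on an aromatic carbon); that change made a 5.2-fold higher number from compound 3 to compound 2 (0.72 log units; beyond the scatter).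

Compound 4, `CCCc1ccc(C2NC(=O)NC(C)=C2C(=O)OCC)cc1`, has not been measured. It relates to compound 1 exactly as compound 2 relates to compound 3: propyl in place of methylsulfanyl on an aromatic carbon. The difference between the core of compound 1 and the core of compound 3 is not broken down here. Going by the values given here, because a 5.2-fold higher number from compound 3 to compound 2 (0.72 log units; beyond the scatter) is the one measured example of this same change, a step of similar size is expected from compound 1 to compound 4, namely a 5.2-fold higher number from compound 1 to compound 4 (0.72 log units; beyond the scatter). Among the compounds with values here, with only one prior example, the range is kept wide. For compound 4 the expected value in this assay is 13 ug/mL, between 6 ug/mL and 28 ug/mL.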

Compound 4, concentration for 50% growth inhibition: 18.8 ug/mL
Estimate against measurement, compound 4: 1.4-fold (0.16 log units) below; the range from low to high includes it.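

In this assay, replacing methylsulfanyl with propyl also weakens growth inhibition on the core of compound 1, giving a 7.5-fold higher number from compound 1 to compound 4 (0.88 log units; beyond the scatter). The two cores cannot be told apart by how much this change moves the number: the same change on two cores in this assay, a 5.2-fold higher number (0.72 log units; beyond the scatter) from compound 3 to compound 2 and a 7.5-fold higher number (0.88 log units; beyond the scatter) from compound 1 to compound 4, 1.4-fold (0.16 log units) apart, within the scatter of two such steps. For these two cores, then, the size of the step carried over from one to the other, but two pairs are a small sample, and they show neither why propyl gives the higher number nor whether the step would hold on any other core.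

The compounds shown carry only methylsulfanyl or propyl on this aromatic carbon, which leaves open what a methoxy group, a longer chain such as pentyl, or an amine would do there. Going by these compounds, it also remains open whether a step of similar size would appear in a growth test on a different cell line.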